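Removing the Methyl from the Methoxy of Compound 2

The source may report more compounds than this note shows. Statements on the series, on what has been measured and on what is new or still open speak of the compounds shown alone.

Going by the values given here, the compounds measured so far in an ADME assay on MDBK cells (Bos taurus) for cytotoxicity, read by MTT assay, with a stated time of 96 h (on this read-out higher numbers stand for lower toxicity in this test and lower numbers for higher toxicity in this test), are these.
Compound 1, `COc1ccc(-c2nc3cc(Cl)c(Cl)cc3[nH]2)c(N)c1`, gives 6500 nM.
Compound 2, `COc1ccc(-c2nc3cc(Cl)c(Cl)cc3[nH]2)cc1`, gives 2500 nM.
Compound 3, `O=C(CCl)Nc1ccc(-c2nc3cc(C(F)(F)F)ccc3[nH]2)cc1`, gives 17000 nM.

Compound 2 stands at the lowest of these three numbers, that is, it is the most toxic of the three in this assay. Compound 1 is its nearest neighbour, and compound 3, which carries a different core and a different side group, lies furthest away at 17000 nM.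

The new compound is compound 4, `Oc1ccc(-c2nc3cc(Cl)c(Cl)cc3[nH]2)cc1`. It differs from compound 2 in one place: hydrogen in place of methyl on an oxygen on an aromatic ring.

Only one measured step exists among these compounds, a 2.6-fold lower number from compound 1 to compound 2 (0.41 log units; beyond the scatter), and it concerns a different group on the shared core, not the oxygen-bound methyl. Among the compounds with values here, no measured pair shows what taking a methyl off this oxygen does. With nothing to point either way, the expected step for compound 4 in this assay is small, a 1.2-fold higher number from compound 2 to compound 4 (0.08 log units; within the scatter), a change that is not expected to go beyond the scatter.

Compound 4 is therefore estimated at 3000 nM, within a range from 1200 nM to 8000 nM.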

Compound 4, half-maximal cytotoxic concentration: 11000 nM
Beside the measured number, compound 4's estimate is 3.7-fold (0.56 log units) below it, outside the stated range (above it).
By their numbers in this assay, from the lowest: compound 2; then compounds 1, 4 and 3 (each within the scatter of the next, the first and the last beyond it).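

In this assay, the change from methoxy to hydroxy gives a 4.4-fold higher number from compound 2 to compound 4 (0.64 log units; beyond the scatter), which on this read-out means lower toxicity in this test. Going by these compounds alone, this is the first measured pair that touches this oxygen, and it shows that the methyl here is not a silent detail: taking away this one small group, with the rest of the molecule left unchanged, is enough to move the number beyond the usual scatter. No measurement at hand accounts for this step, so the pair records what happens and not why it happens.

The compounds shown leave open whether a longer chain on this oxygen, such as an ethyl group, or an amine in place of the hydroxy would give a number closer to that of compound 2 or to that of compound 4. They also leave open whether the change from methoxy to hydroxy would have a similar size on a molecule that also carries the amino group of compound 1.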